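Isopropyl on the Phenyl Arm of Compound 1

This account rests on a few compounds, and the source may have more. Where it says the series, first, only, none or still open, it means among the compounds named here.

Compound 1 `COc1ccc(Nc2nc(SCc3cn(Cc4ccccc4Cl)nn3)nc(-c3ccccc3)c2C#N)cc1` gives 7960 nM in a functional assay on ECa-109 cells (Homo sapiens) for inhibition, read by MTT assay, with a stated time of 72 h (on this read-out higher numbers stand for weaker inhibition and lower numbers for stronger inhibition), the lowest of the three numbers shown, although its gap to compound 2 lies within the scatter. Compound 2 `COc1ccccc1Nc1nc(SCc2cn(Cc3ccccc3Cl)nn2)nc(-c2ccccc2)c1C#N` gives 9670 nM in this assay, and a 1.2-fold higher number from compound 1 to compound 2 (0.08 log units; within the scatter) does not separate the two. Compound 3 `N#Cc1c(Nc2ccccc2F)nc(SCc2cn(Cc3ccccc3Cl)nn2)nc1-c1ccccc1` gives 23000 nM in this assay; the steps of a 2.9-fold higher number from compound 1 to compound 3 (0.46 log units; beyond the scatter) and a 2.4-fold higher number from compound 2 to compound 3 (0.38 log units; beyond the scatter) both exceed the scatter, though only modestly. Compound 4 `COc1ccc(Nc2nc(SCc3cn(Cc4ccccc4Cl)nn3)nc(-c3ccc(C(C)C)cc3)c2C#N)cc1` differs from compound 1 by isopropyl in place of hydrogen on an aromatic carbon. Going by the values given here, every measured step concerns the aryl group on the nitrogen; none touches the phenyl that carries the new group, so no measured step bears directly on this change. The steps that were measured were small to modest, and nothing in the data points to a larger movement here. The step of a 1.1-fold lower number from compound 1 to compound 4 (0.06 log units; within the scatter) is therefore expected to stay within the scatter or only just beyond it, in either direction. Compound 4 is expected to give about 7000 nM in this assay, with a range from 2500 nM to 20000 nM.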

Compound 4, half-maximal inhibitory concentration: 3580 nM
For compound 4 the middle estimate is 2.0-fold (0.29 log units) above the measured one; the range from low to high includes it.
By their numbers in this assay, from the lowest: compound 4; then compounds 1 and 2 (each within the scatter of the next); then compound 3.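

Going by these compounds alone, the step of a 2.2-fold lower number from compound 1 to compound 4 (0.35 log units; beyond the scatter) is the first reading in this assay on the phenyl arm itself, whereas every earlier step concerned the aryl group on the nitrogen. It shows that isopropyl can stand on this aromatic carbon, para to a large group, without loss, and that the number moves down, if only modestly. No measurement shown bears on why the number moved.

The compounds shown leave open whether this step belongs to isopropyl in particular, or whether methyl, a longer chain, an amine or a carboxylic acid at the same place would give a similar one. They also leave open whether isopropyl would give a like step with the aryl groups on the nitrogen of compound 2 and compound 3.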